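Nitroimidazole oxadiazole thioethers: aryl swap to aminopyridine

The compounds below may be only part of what the source reports. "The series", "measured", "known", "first", "only" and "open" are said of these compounds alone.

Measured compounds and cytotoxicity numbers:
compound 1 `Cc1ccccc1-c1nnc(SCCn2c([N+](=O)[O-])cnc2C)o1`, 15800 nM
compound 2 `Cc1ncc([N+](=O)[O-])n1CCSc1nnc(-c2ccccc2F)o1`, 20500 nM
compound 3 `Cc1ncc([N+](=O)[O-])n1CCSc1nnc(-c2ccc(Cl)cc2)o1`, 18700 nM

All three share one core and differ only in the aryl group on the oxadiazole. In a functional assay on MCF7 cells (Homo sapiens) for cytotoxicity, read by MTT assay, with a stated time of 48 h (on this read-out higher numbers stand for weaker inhibition and lower numbers for stronger inhibition), compound 1 gives 15800 nM, the lowest of the three numbers, but the steps to the others are small: a 1.3-fold higher number from compound 1 to compound 2 (0.11 log units; within the scatter) and a 1.2-fold higher number from compound 1 to compound 3 (0.07 log units; within the scatter), both within the scatter, as is a 1.1-fold lower number from compound 2 to compound 3 (0.04 log units; within the scatter). On these data the three aryl variants cannot be told apart.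

Compound 4 `Cc1ncc([N+](=O)[O-])n1CCSc1nnc(-c2cnccc2N)o1`, not yet measured, carries the change (4-aminopyridin-3-yl in place of 2-methylphenyl on an aromatic carbon). Going by the values given here, none of the measured steps introduces a ring nitrogen or a hydrogen-bond donor on this aryl group, so no step bears directly on it; the steps that exist, a fluoro for a methyl and a 4-chlorophenyl for either, all stayed within the scatter. The expectation for this assay is therefore a step of no clear size beyond the scatter, with the direction open. The estimate for compound 4 is 18000 nM, with a range from 6000 nM to 55000 nM, which as a step from compound 1 means a 1.1-fold higher number from compound 1 to compound 4 (0.06 log units; within the scatter), an expected change that is essentially none.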

Compound 4, half-maximal inhibitory concentration: 29300 nM
Estimate against measurement, compound 4: 1.6-fold (0.21 log units) below; measured number inside the range.
By their numbers in this assay, from the lowest: compounds 1, 3, 2 and 4 (each within the scatter of the next).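

In this assay, the 4-aminopyridin-3-yl group of compound 4 stays within the scatter of the 2-methylphenyl (a 1.9-fold higher number from compound 1 to compound 4 (0.27 log units; within the scatter)), 4-chlorophenyl (a 1.6-fold higher number from compound 3 to compound 4 (0.20 log units; within the scatter)) and 2-fluorophenyl (a 1.4-fold higher number from compound 2 to compound 4 (0.16 log units; within the scatter)) groups. The earlier compounds shown here varied only substituents on a six-membered aromatic ring of carbon only, whereas this change adds a ring hetero atom, a hydrogen-bond donor and hydrogen-bond acceptors at the same aromatic carbon, and still gives no step beyond the scatter, so this wider change does not separate compound 4 from the other three compounds. Nothing on hand bears on why the numbers fall as they do, and no property of these aryl groups has been measured.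

A pyridine ring without the amine and a phenyl ring carrying an amine are not among the compounds shown, so the ring nitrogen and the amine cannot be read apart. Going by these compounds, it also remains open whether a carboxylic acid on the aryl ring, or a morpholine or a longer alkyl chain in place of the aryl group, would give a step beyond the scatter.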